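The source may hold more compounds than are shown below. What is called first, only, known or untested is meant among the compounds shown, and "the series" means these compounds.

Compound 1 `Oc1cccc(-c2cc(-c3ccc(Cl)cc3)nc(-c3ccsc3)c2)c1`: 11.7%
Compound 2 `Oc1cccc(-c2cc(-c3ccccc3)nc(-c3ccc(Cl)cc3)c2)c1`: 7.1%
Compound 3 `Oc1cccc(-c2cc(-c3ccccc3)nc(-c3ccccc3Cl)c2)c1`: 3.2%

All three were tested in an assay on isolated protein for inhibition of DNA topoisomerase 1 (Homo sapiens), with a stated time of 30 min, tested at 100 uM; a lower number here means a weaker effect, a higher number a stronger effect of the compound at the concentration tested. Compound 1 and compound 2 differ in one group (thiophen-3-yl in place of phenyl on an aromatic carbon), and the step was a number 4.6 percentage points higher from compound 2 to compound 1 (within the scatter). Compound 2 and compound 3 differ in how their cores are built (2-chlorophenyl in place of 4-chlorophenyl on an aromatic carbon), and the step was a number 3.9 percentage points lower from compound 2 to compound 3 (within the scatter). Compound 4 `Oc1cccc(-c2cc(-c3ccsc3)nc(-c3ccccc3Cl)c2)c1` has not been measured; it differs from compound 3 in one place (thiophen-3-yl in place of phenyl on an aromatic carbon). This is the same kind of change as that made from compound 2 to compound 1, though around the place it is meta to a 2-chlorophenyl group rather than meta to a 4-chlorophenyl group. Compound 4 is expected to move by a number 3.8 percentage points higher from compound 3 to compound 4 (within the scatter), an expectation resting on the single earlier case of this change a number 4.6 percentage points higher from compound 2 to compound 1 (within the scatter). Compound 4 is therefore estimated at 7%, with a range from -5% to 20%.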

Compound 4, a percentage reported as inhibition, at one concentration (the size of the read-out at that concentration, not a potency): 0%
Compound 4: middle estimate off by 7 percentage points, on the high side, within the range that was stated.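

The thiophen-3-yl change gave a number 3.2 percentage points lower from compound 3 to compound 4 (within the scatter), and this does not differ from its earlier case: the same change on two cores in this assay, a number 4.6 percentage points higher (within the scatter) from compound 2 to compound 1 and a number 3.2 percentage points lower (within the scatter) from compound 3 to compound 4, 7.8 percentage points apart, within the scatter of two such steps

The 2-chlorophenyl change gave a number 11.7 percentage points lower from compound 1 to compound 4 (beyond the scatter), and this also agrees with its earlier case: the same change on two cores in this assay, a number 3.9 percentage points lower (within the scatter) from compound 2 to compound 3 and a number 11.7 percentage points lower (beyond the scatter) from compound 1 to compound 4, 7.8 percentage points apart, within the scatter of two such steps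

So neither change is shown to behave differently on the two cores, but with only two cases of each and small read-outs, this does not show that either change has the same effect on every core in this series.

The compounds shown leave open how this assay would respond to an amine or a carboxylic acid in place of the chlorine. They also leave open the effect of a methoxy group in place of the hydroxyl of the 3-hydroxyphenyl group.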